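Hydroxy to methoxy on compound 1

The compounds below may be only part of what the source reports. "The series", "measured", "known", "first", "only" and "open" are said of these compounds alone.

- compound 1 `O=C(NCCCNc1cc(-c2cn(-c3ccccc3)nc2-c2cccc(O)c2)ccn1)Nc1ccc(F)cc1`: 2180 nM
- compound 2 `O=C(NCCCNc1cc(-c2cn(-c3ccccc3)nc2-c2cccc(O)c2)ccn1)Nc1cccc(C(F)(F)F)c1`: 3260 nM

Both compounds were tested in a functional assay on BT-549 cells (Homo sapiens) for antiproliferative activity, read by sulforhodamine B assay, with a stated time of 48 h; a lower number here means a stronger inhibitor, a higher number a weaker inhibitor. Among the compounds with values here, the only measured step is a 1.5-fold higher number from compound 1 to compound 2 (0.17 log units; within the scatter), so compound 1 stands level with compound 2 on these numbers.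

Compound 3 `COc1cccc(-c2nn(-c3ccccc3)cc2-c2ccnc(NCCCNC(=O)Nc3ccc(F)cc3)c2)c1` has not yet been measured. It keeps the core of compound 1 and differs in one place: methyl in place of hydrogen on an oxygen on an aromatic ring. This is the change from 3-hydroxyphenyl to 3-methoxyphenyl, a methyl in place of hydrogen on an oxygen on an aromatic ring.

The measured step does not touch this oxygen. It exchanges 4-fluorophenyl for 3-(trifluoromethyl)phenyl on an amide-type nitrogen, so it gives no direct size for the new change. Within the data shown here, no measured pair tests hydroxy against methoxy, which leaves the expectation in this assay loose. Among the measured compounds shown here, no step clearly beyond the scatter is expected, with a slight lean towards a higher number, and compound 1 at 2180 nM serves as the anchor.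

The expected change is a 1.4-fold higher number from compound 1 to compound 3 (0.14 log units; within the scatter).

The estimate for compound 3 is 3000 nM, with an expected range from 1000 nM to 9000 nM.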

Compound 3, half-maximal inhibitory concentration: 6240 nM
The estimate for compound 3 lay 2.1-fold (0.32 log units) below the measured number; the measured number falls inside the stated range.
By their numbers in this assay, from the lowest: compounds 1, 2 and 3 (each within the scatter of the next, the first and the last beyond it).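

In this assay the methyl on the oxygen of the 3-hydroxyphenyl group gives a 2.9-fold higher number from compound 1 to compound 3 (0.46 log units; beyond the scatter), a modest step and the only one shown that lies beyond the scatter. Within the data shown here, the earlier step changed only the aryl group on the amide-type nitrogen and stayed within the scatter, so this oxygen is the first place in these compounds where a single change clearly moves the number, with the free hydroxy on the side of the lower number. No supporting measurement is available to account for this step.

As far as these compounds go, it remains open whether a larger group on the same oxygen, such as ethyl, would raise the number further, or whether an amine in place of the hydroxy would stay close to compound 1. From the compounds shown here alone, it is also open whether the hydroxy to methoxy change would have a step of similar size with 3-(trifluoromethyl)phenyl on the amide-type nitrogen, as in compound 2, since this change has so far been read only with 4-fluorophenyl there.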